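The compounds below may be only part of what the source reports. "The series", "measured", "known", "first", "only" and "open" are said of these compounds alone.

Measured so far, in a functional assay on CRL2813 cells (Homo sapiens) for cytotoxicity, read by sulforhodamine B assay, with a stated time of 5 days; on this read-out higher numbers stand for weaker inhibition and lower numbers for stronger inhibition:
- compound 1, `O=C(Nc1ccccc1F)N[C@H]1CC[C@H](Oc2ccc(F)cc2)CC1`, gives 17500 nM.
- compound 2, `Cc1ccccc1NC(=O)N[C@H]1CC[C@H](Oc2ccc(F)cc2)CC1`, gives > 20000 nM, which is a limit of this assay and not a number.
- compound 3, `O=C(Nc1ccccc1)N[C@H]1CC[C@H](Oc2ccc(F)cc2)CC1`, gives 20000 nM.

Among the measured compounds shown here, compound 3 sits with compound 1 inside the scatter, the step being a 1.1-fold higher number from compound 1 to compound 3 (0.06 log units; within the scatter); the only other value shown is the limit noted for compound 2, as recorded at the limit of > 20000 nM in this assay, at which 1 of the 3 values shown sits. Against compound 2 the step reads a number no higher from compound 2 to compound 3 (the limit leaves the size open), so its size cannot be read.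

Compound 4, `CSc1cccc(NC(=O)N[C@H]2CC[C@H](Oc3ccc(F)cc3)CC2)c1`, is to be measured in this assay. It differs from compound 3 in one place: methylsulfanyl in place of hydrogen on an aromatic carbon.

For the measured compounds named here, the steps that bear on this are the two changes of a substituent on the same aromatic ring: a 1.1-fold higher number from compound 1 to compound 3 (0.06 log units; within the scatter) and a number no higher from compound 2 to compound 3 (the limit leaves the size open), one within the scatter and one with its size left open. Nothing among them moves the number beyond the scatter, so the expectation for the step of no change at the digits printed from compound 3 to compound 4 (within the scatter) is no change beyond the scatter. Compound 4 is therefore estimated at 20000 nM, between 8000 nM and 40000 nM.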

Compound 4, half-maximal inhibitory concentration: 11100 nM
Beside the measured number, compound 4's estimate is 1.8-fold (0.26 log units) above it; the range from low to high includes it.
By their numbers in this assay, from the lowest: compounds 4, 1 and 3 (each within the scatter of the next).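

In this assay, the first group shown on the aromatic carbon meta to a large group, methylsulfanyl, gives a 1.8-fold lower number from compound 3 to compound 4 (0.26 log units; within the scatter), so a sulfur-bearing group is accommodated at this place without a shift beyond the scatter. The change from the earlier 2-substituted phenyl groups to 3-(methylsulfanyl)phenyl gives a 1.6-fold lower number from compound 1 to compound 4 (0.20 log units; within the scatter) and also an at least 1.8-fold lower number from compound 2 to compound 4 (0.25 log units; that floor lies within the scatter). For the second of these steps, the size is only a floor, set by a limit of the assay for compound 2: the limit of > 20000 nM in this assay, at which 1 of the 4 values shown sits.

No readable step among the compounds shown goes beyond the scatter, so it remains open whether any change on this ring can move the number beyond it. From the compounds shown here alone, how an amine, a carboxylic acid or a longer chain at this place would read also stays open.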